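From 3,4-difluorophenyl to 2,3,4-trifluorophenyl: working notes

The source may report more compounds than this note shows. Statements on the series, on what has been measured and on what is new or still open speak of the compounds shown alone.

Values so far in a functional assay with Homo sapiens as the target (on this read-out higher numbers stand for weaker inhibition and lower numbers for stronger inhibition), for each compound:
- compound 1 (`CC(C)[C@H](NC(=O)COc1cccc2ccccc12)C(=O)N[C@@H](CC(=O)O)C(=O)COc1ccccc1C(F)(F)F`) 17300 nM
- compound 2 (`CC(C)[C@H](NC(=O)COc1cccc2ccccc12)C(=O)N[C@@H](CC(=O)O)C(=O)COc1ccc([N+](=O)[O-])cc1`) 22800 nM
- compound 3 (`CC(C)[C@H](NC(=O)COc1cccc2ccccc12)C(=O)N[C@@H](CC(=O)O)C(=O)COc1ccc(F)c(F)c1`) 16200 nM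

Compound 3 lies within the scatter of both other compounds, so none of the three stands apart. Compound 4 (`CC(C)[C@H](NC(=O)COc1cccc2ccccc12)C(=O)N[C@@H](CC(=O)O)C(=O)COc1ccc(F)c(F)c1F`) has fluoro in place of hydrogen on an aromatic carbon which turns 3,4-difluorophenyl to 2,3,4-trifluorophenyl. The nearest evidence is the exchange of the group on the oxygen: a 1.1-fold lower number from compound 1 to compound 3 (0.03 log units; within the scatter) then a 1.4-fold lower number from compound 2 to compound 3 (0.15 log units; within the scatter) and a 1.3-fold higher number from compound 1 to compound 2 (0.12 log units; within the scatter) all stay small. The expected change is therefore a 1.1-fold lower number from compound 3 to compound 4 (0.03 log units; within the scatter) with no step beyond the scatter expected in this assay for this change. Compound 4 is estimated at 15000 nM with an expected range of 8000 nM to 28000 nM on this read-out.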

Compound 4, half-maximal inhibitory concentration: 20600 nM
Compound 4: middle estimate off by 1.4-fold (0.14 log units), on the low side; the measured number falls inside the stated range.
By their numbers in this assay, from the lowest: compounds 3, 1, 4 and 2 (each within the scatter of the next).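

In this assay, fluoro on the aromatic carbon ortho to a fluoro group and ortho to a large group gives a step within the scatter (a 1.3-fold higher number from compound 3 to compound 4 (0.10 log units; within the scatter)). Compound 4 also stays within the scatter of the other two aryl ethers (a 1.1-fold lower number from compound 2 to compound 4 (0.04 log units; within the scatter); a 1.2-fold higher number from compound 1 to compound 4 (0.08 log units; within the scatter)), so 2,3,4-trifluorophenyl reads alike with all three groups on this oxygen. No measurement at hand accounts for this flat picture. Open, from the compounds shown here alone, is whether an amine or a methoxy group on this same aromatic carbon would also stay within the scatter.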